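Notes on the carbonyl substituent step from compound 2 to compound 4

A few compounds are considered here, and "the series" means these few. Any claim that something is new, unique, unknown or untested is made for them only; others in the source may bear on it.

Compound 1 `COc1cc(NCc2ccccc2)cc(OC)c1OC` is the smallest member of the set. In a functional assay on HCT-116 cells (Homo sapiens) for inhibition, read by MTT assay, with a stated time of 48 h (on this read-out higher numbers stand for weaker inhibition and lower numbers for stronger inhibition), compound 1 gives > 80000 nM, which is a limit of the assay and not a number. Compound 3 `COc1cc(NCc2ccc(Br)cc2)cc(OC)c1OC` in this assay gives > 80000 nM, again a limit. The step that the two limits leave unreadable from compound 1 to compound 3 is therefore unreadable, because of the limit of > 80000 nM in this assay, at which 2 of the 3 values shown sit. Compound 2 `COc1ccc(CN(C(=O)C=C(C)C)c2cc(OC)c(OC)c(OC)c2)cc1O` in this assay gives 290 nM, the only number shown. Compound 2 is thus the sole anchor for any expectation.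

Compound 4 `COc1ccc(CN(C(=O)/C=C/CBr)c2cc(OC)c(OC)c(OC)c2)cc1O` differs from compound 2 in one place: 3-bromoprop-1-en-1-yl in place of 2-methylprop-1-en-1-yl on a carbonyl carbon. Among the compounds with values here, no measured step touches the substituent on the carbonyl carbon; the one readable pair concerns a bromo in place of hydrogen on an aromatic carbon, and its size cannot be read. The expectation for the step from compound 2 to compound 4 is thus set at no change beyond the scatter, a 1.4-fold higher number from compound 2 to compound 4 (0.14 log units; within the scatter), with the direction open. Compound 4 is estimated at 400 nM in this assay, within 90 nM to 3000 nM.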

Compound 4, half-maximal inhibitory concentration: 59 nM
Compound 4: the middle estimate sits 6.8-fold (0.83 log units) above what was measured, outside the stated range (below it).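

In this assay, within the data shown here, the substituent on the carbonyl carbon turns out to be a position that can move the read-out: the exchange gives a 4.9-fold lower number from compound 2 to compound 4 (0.69 log units; beyond the scatter) and is the first step whose size can be read. The entering and leaving groups match in their count of heavy atoms and in their one double bond outside aromatic rings, so a change that leaves those counts the same still carries the number beyond the scatter. Nothing shown here gives a reason for this step.

As far as these compounds go, whether the step follows the bromine or the altered chain remains open. A 3-chloroprop-1-en-1-yl group, a plain prop-1-en-1-yl group or an amine at the end of the chain on this carbonyl carbon would bear on that question.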